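Moving the Nitrile on the Benzyl Ester of Compound 2

The source may report more compounds than this note shows. Statements on the series, on what has been measured and on what is new or still open speak of the compounds shown alone.

Among the compounds with values here, compound 2 `COc1ccc(-c2csc(N)c2C(=O)OCc2cccc(C#N)c2)cc1OC` gives 70% in an assay on isolated protein for inhibition of protein kinase C zeta type (Homo sapiens), with stated times of 1 h and 2.5 min, tested at 30 uM (a lower number here means less inhibition, a higher number more inhibition at the concentration tested (going by the name of the read-out)), the lowest of the two numbers measured so far; compound 1 `CCOC(=O)c1c(-c2ccc(OC)c(OC)c2)csc1N` gives 100%. Within the data shown here, the only measured step, a number 30 percentage points lower from compound 1 to compound 2 (beyond the scatter), concerns a different change and therefore bears only loosely on what follows. Compound 3 `COc1ccc(-c2csc(N)c2C(=O)OCc2ccc(C#N)cc2)cc1OC` differs from compound 2 by 4-cyanophenyl in place of 3-cyanophenyl on a saturated chain carbon bound to an oxygen next to a carbonyl group. Among the measured compounds shown here, no measured step tests this particular shift, so no step beyond the scatter is expected, no change at the digits printed from compound 2 to compound 3 (within the scatter). Compound 3 is accordingly estimated at 70%, with a range from 45% to 92%.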

Compound 3, a percentage reported as inhibition, at one concentration (the size of the read-out at that concentration, not a potency): 10%
Compound 3: middle estimate off by 60 percentage points, on the high side, outside the stated range (below it).
By their numbers in this assay, from the lowest: compound 3; then compound 2; then compound 1.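

In this assay, the two isomers are far apart: 4-cyanophenyl in place of 3-cyanophenyl gives a number 60 percentage points lower from compound 2 to compound 3 (beyond the scatter) on the saturated chain carbon, so where the nitrile sits on this ring matters and not merely its presence. Set against methyl at that carbon, 4-cyanophenyl gives a number 90 percentage points lower from compound 1 to compound 3 (beyond the scatter) with the rest of the molecule unchanged. Nothing at hand accounts for the gap between the two isomers.

On these data alone, whether an amine or a carboxylic acid in place of the nitrile would track compound 2 or compound 3 stays open, as does the effect of a plain benzyl group.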